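A few compounds are considered here, and "the series" means these few. Any claim that something is new, unique, unknown or untested is made for them only; others in the source may bear on it.

Within the data shown here, in a functional assay on QG-56 cells (Homo sapiens) for antiproliferative activity (a lower number here means a stronger inhibitor, a higher number a weaker inhibitor), compound 3 `Cn1cncc1C(O)(c1ccc(C#N)cc1)c1cc2cc([N+](=O)[O-])cc(-c3ccccc3)c2o1` gives 1480 nM, the highest number of the three measured so far, with its steps to both others beyond the scatter. Compound 1 `COc1cccc(-c2cc([N+](=O)[O-])cc3cc(C(O)(c4ccc(C#N)cc4)c4cncn4C)oc23)c1` gives 38.8 nM, and compound 2 `Cn1cncc1C(O)(c1ccc(C#N)cc1)c1cc2cc([N+](=O)[O-])cc(-c3ccccc3F)c2o1` gives 89.5 nM. Compound 4 `Cc1cccc(-c2cc([N+](=O)[O-])cc3cc(C(O)(c4ccc(C#N)cc4)c4cncn4C)oc23)c1` has not yet been measured. It differs from compound 3 by one change, methyl in place of hydrogen on an aromatic carbon, turning phenyl into 3-methylphenyl. Among the measured compounds shown here, two measured steps bear on this change. Removing the methoxy of the 3-methoxyphenyl group gives a 38-fold higher number from compound 1 to compound 3 (1.58 log units; beyond the scatter), and removing the fluoro of the 2-fluorophenyl group gives a 17-fold higher number from compound 2 to compound 3 (1.22 log units; beyond the scatter). Both are large and both end at the unsubstituted phenyl, so adding a group here may be read as lowering the number. For the measured compounds named here, no measured compound carries methyl, however, so the size remains uncertain. A large step downward is therefore expected, an estimated 12-fold lower number from compound 3 to compound 4 (1.09 log units; beyond the scatter). For compound 4 the expected value is 120 nM, with an estimated range from 35 nM to 600 nM.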

Compound 4, half-maximal inhibitory concentration: 23.2 nM
Estimate against measurement, compound 4: 5.2-fold (0.71 log units) above, outside the stated range (below it).
By their numbers in this assay, from the lowest: compounds 4 and 1 (each within the scatter of the next); then compound 2; then compound 3.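

In this assay, turning phenyl into 3-methylphenyl gives a 64-fold lower number from compound 3 to compound 4 (1.80 log units; beyond the scatter), so a single carbon is enough for a large drop at this position, and neither oxygen nor fluorine is needed for it. Methyl and methoxy on this ring are not separated by the assay, with a 1.7-fold lower number from compound 1 to compound 4 (0.22 log units; within the scatter). The swap of 3-methylphenyl in place of 2-fluorophenyl gives a 3.9-fold lower number from compound 2 to compound 4 (0.59 log units; beyond the scatter), a step that changes the group and where it sits together, so the two contributions cannot be told apart.

No measurement at hand accounts for the size of these steps. The compounds shown leave open whether a longer chain such as ethyl or propyl, an amine or a chlorine atom in the same place would keep the number as low.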